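The compounds below may be only part of what the source reports. "The series", "measured", "known", "first", "only" and "open" are said of these compounds alone.

Compound 1 `COc1ccc(Nc2cc(/C=C/c3ccccc3)oc(=O)c2)cc1`: 0.15 uM
Compound 2 `COc1ccc(Nc2cc(-c3ccco3)oc(=O)c2)cc1`: 2.66 uM

In a functional assay on KB cells (Homo sapiens) for cytotoxicity, read by MTT assay, with a stated time of 72 h (on this read-out higher numbers stand for an effect only at larger amounts of compound and lower numbers for an effect already at smaller amounts), compound 1 gives 0.15 uM and compound 2 gives 2.66 uM. Going by the values given here, compound 2 thus stands at the higher of the two numbers, separated from compound 1 by the single measured step, an 18-fold higher number from compound 1 to compound 2 (1.25 log units; beyond the scatter). Compound 3 `COc1ccc(Nc2cc(C3CCCC3)oc(=O)c2)cc1` differs from compound 2 by cyclopentyl in place of furan-2-yl on an aromatic carbon. Among the compounds with values here, no measured step replaces the furan-2-yl with a non-aromatic ring, so the step from compound 1 to compound 2 bears on this change only loosely: it shows that the group at this position can shift the number by a large amount, and that compound 2 already carries the weaker of the two groups seen. A modest further rise, beyond the scatter but with wide uncertainty, is expected for a 2.1-fold higher number from compound 2 to compound 3 (0.32 log units; beyond the scatter) in this assay. Compound 3 is therefore estimated at 5.5 uM in this assay, within a range of 1.5 uM to 20 uM.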

Compound 3, concentration for half-maximal effect: 8.38 uM
Compound 3: middle estimate off by 1.5-fold (0.18 log units), on the low side; the range from low to high includes it.
By their numbers in this assay, from the lowest: compound 1; then compound 2; then compound 3.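

In this assay, cyclopentyl in place of furan-2-yl gives a 3.2-fold higher number from compound 2 to compound 3 (0.50 log units; beyond the scatter), so a five-membered non-aromatic ring of carbon only stands above the five-membered aromatic ring with its hetero atom, although the count of heavy atoms stays the same. With a 56-fold higher number from compound 1 to compound 3 (1.75 log units; beyond the scatter), the three groups at this position now form an order in this assay, with all their steps beyond the scatter: 2-phenylethenyl gives the lowest number, furan-2-yl the middle one and cyclopentyl the highest. No measured information at hand accounts for these differences.

Going by these compounds alone, the single step from compound 2 to compound 3 changes the ring oxygen and the aromatic character together, so it cannot separate the two. From the compounds shown here alone, it also stays open how a plain phenyl ring, a longer chain such as pentyl or an amine such as piperidin-4-yl would stand here.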